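Swapping a Cyclopropyl for a Methoxyphenyl on the Ring Nitrogen

The source may hold more compounds than are shown below. What is called first, only, known or untested is meant among the compounds shown, and "the series" means these compounds.

Compound 1 `O=C1COc2ccc(-c3cccc(NS(=O)(=O)c4ccc(F)cc4)c3)cc2N1C1CC1` carries a cyclopropyl on an amide-type nitrogen in a ring of the shared core. In a functional assay on A549 cells (Homo sapiens) for antiproliferative activity, read by MTT assay, with a stated time of 72 h (on this read-out higher numbers stand for weaker inhibition and lower numbers for stronger inhibition), compound 1 gives > 40000 nM, which is a limit of the assay rather than a measured number. A second compound, compound 2 `O=C1COc2ccc(-c3cnc(Cl)c(NS(=O)(=O)c4ccc(F)cc4)c3)cc2N1`, in this assay gives > 40000 nM, again only a limit. So compound 1 stands at the limit, and the one further value shown sits there as well (the limit of > 40000 nM in this assay, at which 2 of the 2 values shown sit); no measured number separates these two compounds, and no step between them is known.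

Compound 3 `COc1ccc(N2C(=O)COc3ccc(-c4cccc(NS(=O)(=O)c5ccc(F)cc5)c4)cc32)cc1` is the compound still to be tested. Its change from compound 1 is 4-methoxyphenyl in place of cyclopropyl on an amide-type nitrogen in a ring. Going by the values given here, no measured pair shows what this exchange does in this assay, so the size and direction of the step cannot be read from any measured step. With both measured compounds sitting at the limit, the expectation is that compound 3 stays near that limit, with a number no higher from compound 1 to compound 3 (the limit leaves the size open) as the expected step. Compound 3 is estimated at 40000 nM in this assay, within a range from 8000 nM to 150000 nM.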

Compound 3, half-maximal inhibitory concentration: 38200 nM
Compound 3: the middle estimate sits 1.0-fold (0.02 log units) above what was measured; the measured number falls inside the stated range.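

In this assay, compound 3 gives a true measured number, 38200 nM, so this position now has one value that is not a limit. Placing 4-methoxyphenyl on the amide-type nitrogen in a ring, where cyclopropyl stood, yields an at least 1.0-fold lower number from compound 1 to compound 3 (0.01 log units; that floor lies within the scatter); because that is only a floor within the usual scatter, it shows no real gain, only that the larger aromatic group leaves the result in the same region of the assay. This region is where most of the values shown lie, and the measured number for compound 3 does little to change that picture: the limit of > 40000 nM in this assay, at which 2 of the 3 values shown sit.

From the compounds shown here alone, the true size of the step stays open, since compound 1 has only a limit and the change could be anything from negligible to larger than this floor. Also open, going by these compounds, is what a plain phenyl, a benzyl or a longer chain such as butyl would do on this nitrogen, and so whether the methoxy group of compound 3 matters at all.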